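The source may report more compounds than this note shows. Statements on the series, on what has been measured and on what is new or still open speak of the compounds shown alone.

Three compounds share one core and a methylsulfanyl group: compound 1 `CSc1ccc(OCc2ccc(F)cc2F)c(C2=C(c3cccc(C(=O)O)c3)CCC2)c1`, compound 2 `CSc1ccc(OCc2ccc(F)cc2)c(C2=C(c3cccc(C(=O)O)c3)CCC2)c1` and compound 3 `CSc1ccc(OCc2ccccc2)c(C2=C(c3cccc(C(=O)O)c3)CCC2)c1` differ only in the fluoro substitution of the benzyloxy group. In an assay on isolated protein for inhibition of prostaglandin E2 receptor EP3 subtype (Homo sapiens) (on this read-out higher numbers stand for weaker inhibition and lower numbers for stronger inhibition), compound 1 gives < 3170 nM, which is a limit of the assay and not a number. Compound 2 likewise reaches only a limit, < 3170 nM. Compound 3 too gives only a limit, < 3170 nM. The steps a step that the two limits leave unreadable from compound 1 to compound 2, a step that the two limits leave unreadable from compound 1 to compound 3 and a step that the two limits leave unreadable from compound 2 to compound 3 therefore cannot be read, and the limit of < 3170 nM in this assay, at which 3 of the 3 values shown sit, is all the three values reveal about compound 3's standing. Compound 4 `CS(=O)(=O)c1ccc(OCc2ccccc2)c(C2=C(c3cccc(C(=O)O)c3)CCC2)c1` differs from compound 3 by methylsulfonyl in place of methylsulfanyl on an aromatic carbon. For the measured compounds named here, no measured step bears on this change, since every value so far sits at the limit. The step that the limit leaves unreadable from compound 3 to compound 4 is thus expected to stay unresolved against the scatter. Compound 4 is estimated at 600 nM, within a range from 50 nM to 3170 nM.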

Compound 4, half-maximal inhibitory concentration: < 3170 nM
Compound 4 gave a limit, no number (the forecaster's own chance of this, stated with the estimate: 55%); the middle value lies beyond the limit too.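

Compound 3 and compound 4 each give only a limit and not a number, so no new step can be read between them: the limit of < 3170 nM in this assay, at which 4 of the 4 values shown sit.

The compounds shown leave open what actual value any of them has in this assay, and whether methylsulfonyl and methylsulfanyl differ there at all.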